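The source may report more compounds than this note shows. Statements on the series, on what has been measured and on what is new or still open speak of the compounds shown alone.

Compound 1 `C[C@@H](O)[C@H]1C(=O)N2C(C(=O)OCOC(=O)C3CCCCC3)=C(S[C@@H]3CN[C@H](C(=O)Nc4cccc(C(=O)O)c4)C3)[C@H](C)[C@H]12` is the starting point. In an ADME assay for metabolic stability, read by LC-MS, with a stated time of 3 h, at pH 6.5, tested at 50 uM (on this read-out higher numbers stand for a more stable compound and lower numbers for a less stable compound), compound 1 gives > 95%, and this is a limit of the measurement rather than a number. Compound 2 `C[C@@H](O)[C@H]1C(=O)N2C(C(=O)OCOC(=O)C3CCCCC3)=C(S[C@@H]3CN[C@H](C(=O)Nc4cccc(C(=O)OCOC(=O)C5CCCCC5)c4)C3)[C@H](C)[C@H]12` carries ((cyclohexylcarbonyl)oxy)methyl in place of hydrogen on an oxygen next to a carbonyl group. In this assay compound 2 gives > 95%, again only a limit. Between the two there is a step that the two limits leave unreadable from compound 1 to compound 2. Compound 3 `CC(C)c1oc(=O)oc1COC(=O)C1=C(S[C@@H]2CN[C@H](C(=O)Nc3cccc(C(=O)OCc4oc(=O)oc4C(C)C)c3)C2)[C@H](C)[C@@H]2[C@@H]([C@@H](C)O)C(=O)N12` is the third compound measured. In this assay compound 3 gives > 95%, once more a limit. Among the compounds with values here, every result so far is the limit of > 95% in this assay, at which 3 of the 3 values shown sit, so no sized step is available at all.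

Compound 4 `CC(C)C(=O)OCOC(=O)C1=C(S[C@@H]2CN[C@H](C(=O)Nc3cccc(C(=O)O)c3)C2)[C@H](C)[C@@H]2[C@@H]([C@@H](C)O)C(=O)N12` differs from compound 1 by isopropyl in place of cyclohexyl on a carbonyl carbon. Within the data shown here, no measured pair shows this kind of change, so the only guide is that all three known values sit at the same limit. The step expected is a number no higher from compound 1 to compound 4 (the limit leaves the size open), meaning no change beyond the scatter is anticipated. Compound 4 is therefore estimated at 95%, with a range from 85% to 99%, most likely reported again as a limit.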

Compound 4, percent of the compound remaining: > 95%
Compound 4: only a limit was reported; the forecaster's own chance of this, stated with the estimate: 0.7%; the middle value sits exactly at the limit.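

Within the data shown here, compound 4, like compound 1, is reported only as a limit and not as a number, so no step between these two compounds can be read. The compounds shown leave open whether isopropyl in place of cyclohexyl changes the percent remaining at all, because every result stops at the same point: the limit of > 95% in this assay, at which 4 of the 4 values shown sit.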